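A few compounds are considered here, and "the series" means these few. Any claim that something is new, unique, unknown or untested is made for them only; others in the source may bear on it.

Among the compounds with values here, in a functional assay on A549 cells (Homo sapiens) for antiproliferative activity, read by MTT assay, with a stated time of 24 h (a higher number here means a weaker inhibitor, a lower number a stronger inhibitor), compound 1 (`Cc1ccc(C)c(S(=O)(=O)n2c(-c3cn(-c4ccccc4)nc3-c3ccc(F)cc3)nc3ccccc32)c1`) gives 200 nM and compound 2 (`O=S(=O)(c1ccc(F)cc1)n1c(-c2cn(-c3ccccc3)nc2-c2ccc(F)cc2)nc2ccccc21`) gives 2370 nM as the higher of the two numbers, which places compound 2 at the weaker end of the series so far. Compound 3 (`O=S(=O)(c1ccc(Cl)cc1)n1c(-c2cn(-c3ccccc3)nc2-c2ccc(F)cc2)nc2ccccc21`) follows from compound 2 by chloro in place of fluoro on an aromatic carbon in the form of chloro in place of fluoro on an aromatic carbon, para to a large group. Within the data shown here, one measured step bears on this: a 12-fold higher number from compound 1 to compound 2 (1.07 log units; beyond the scatter) is large and beyond the scatter, but it exchanges a whole 2,5-dimethylphenyl for 4-fluorophenyl on a sulfonyl sulfur. Among the measured compounds shown here, no measured pair isolates a swap of one halogen for another, so only a modest shift towards a lower number is expected. The expected change is a 1.6-fold lower number from compound 2 to compound 3 (0.20 log units; within the scatter) and may not clear the scatter. For compound 3 the estimate is 1500 nM with an expected range of 500 nM to 4000 nM in this assay.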

Compound 3, half-maximal inhibitory concentration: 3170 nM
Compound 3: the middle estimate sits 2.1-fold (0.32 log units) below what was measured; the measured number falls inside the stated range.
By their numbers in this assay, from the lowest: compound 1; then compounds 2 and 3 (each within the scatter of the next).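

In this assay chloro in place of fluoro on this ring, para to a large group, gives a 1.3-fold higher number from compound 2 to compound 3 (0.13 log units; within the scatter) and so leaves the two halogens indistinguishable at this place. With 4-chlorophenyl in place of 2,5-dimethylphenyl on the sulfonyl sulfur there is a 16-fold higher number from compound 1 to compound 3 (1.20 log units; beyond the scatter) and the large gap first seen with 4-fluorophenyl therefore holds for a second halogen. No measurement available here offers an explanation for either step.

The compounds shown do not separate the contribution of the two methyl groups of 2,5-dimethylphenyl from that of the halogen on the 4-halophenyl rings. Unsubstituted phenyl, 4-methylphenyl and 2-methylphenyl on the sulfonyl sulfur would address that question, while a methoxy group or an amine at the halogen's place would test whether this position tolerates anything beyond the two halogens.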